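The source may hold more compounds than are shown below. What is called first, only, known or untested is meant among the compounds shown, and "the series" means these compounds.

Measured in an assay on isolated protein for inhibition of Gonadotropin-releasing hormone receptor (Rattus norvegicus); a lower number here means a stronger inhibitor, a higher number a weaker inhibitor:
compound 1 `CCn1c(SCc2cc([N+](=O)[O-])ccc2OC)nc2cc(NC(=O)NC(C)(C)C)ccc21` gives 170 nM
compound 2 `CCCn1c(SCc2cc([N+](=O)[O-])ccc2OC)nc2cc(NC(=O)NC(C)(C)C)ccc21` gives 120 nM
compound 3 `COc1ccc([N+](=O)[O-])cc1CSc1nc2cc(NC(=O)NC(C)(C)C)ccc2n1C(C)C` gives 62 nM

Compound 2 stands second highest of the three numbers; both steps touching it, a 1.4-fold lower number from compound 1 to compound 2 (0.15 log units; within the scatter) and a 1.9-fold lower number from compound 2 to compound 3 (0.29 log units; within the scatter), stay within the scatter, so no order among these is claimed.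

Compound 4 `CCCn1c(SCc2cc([N+](=O)[O-])ccc2OC)nc2cc(NC(=O)NC(C)(C)C)cc(C(=O)NCc3ccccc3)c21` differs from compound 2 by benzylcarbamoyl in place of hydrogen on an aromatic carbon. Among the measured compounds shown here, none of the measured steps bears on this carbon: a 1.4-fold lower number from compound 1 to compound 2 (0.15 log units; within the scatter), a 2.7-fold lower number from compound 1 to compound 3 (0.44 log units; beyond the scatter) and a 1.9-fold lower number from compound 2 to compound 3 (0.29 log units; within the scatter) all alter the group on the aromatic nitrogen, and only one of them exceeds the scatter. They therefore give no direction for a large new group on the shared core, and the expectation for compound 4 is a value close to that of compound 2 with a wide range, the expected step being no change at the digits printed from compound 2 to compound 4 (within the scatter). Compound 4 is estimated at 120 nM, between 30 nM and 500 nM.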

Compound 4, half-maximal inhibitory concentration: 130 nM
For compound 4 the middle estimate is 1.1-fold (0.03 log units) below the measured one, within the range that was stated.
By their numbers in this assay, from the lowest: compounds 3, 2, 4 and 1 (each within the scatter of the next, the first and the last beyond it).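

In this assay, benzylcarbamoyl on this aromatic carbon, ortho to a fused ring, gives a 1.1-fold higher number from compound 2 to compound 4 (0.03 log units; within the scatter) and so shows that this carbon can carry a group of 10 heavy atoms with no step beyond the scatter. Nothing at hand accounts for this result.

Open, from the compounds shown here alone, is whether a carboxylic acid, an amine or a methylcarbamoyl group on this carbon would also stay within the scatter of compound 2. Also open, going by these compounds, is whether benzylcarbamoyl here gives the same result with isopropyl on the aromatic nitrogen.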